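This account rests on a few compounds, and the source may have more. Where it says the series, first, only, none or still open, it means among the compounds named here.

Compound 1 `Cc1cc(CCC(=O)O)ccc1-c1noc(-c2ccc(OC(C)C)c(F)c2)n1`: 530 nM in a functional assay on CHO cells for agonist activity at sphingosine 1-phosphate receptor 5 (Homo sapiens), read by GTPgammaS binding; a higher number here means that more compound is needed for the effect, a lower number that less compound is needed.
Compound 2 `Cc1cc(CCC(=O)O)ccc1-c1noc(-c2ccc(OC(C)C)c(Cl)c2)n1`: 140 nM.
Compound 3 `COc1cc(-c2nc(-c3ccc(CCC(=O)O)cc3C)no2)ccc1OC(C)C`: 270 nM.

Among these three numbers compound 3 holds the second highest. Its nearest neighbour is compound 2, with a 1.9-fold higher number from compound 2 to compound 3 (0.29 log units; within the scatter); the more distant relation is a 2.0-fold lower number from compound 1 to compound 3 (0.29 log units; within the scatter). Compound 4 `Cc1cc(CCC(=O)O)ccc1-c1noc(-c2ccc(OC(C)C)c(C#N)c2)n1` arises from compound 3 by cyano in place of methoxy on an aromatic carbon. For the measured compounds named here, no measured step exchanges a cyano group, so the guidance is indirect. Going by the values given here, the only clearly resolved step so far is a 3.8-fold lower number from compound 1 to compound 2 (0.58 log units; beyond the scatter), while a 2.0-fold lower number from compound 1 to compound 3 (0.29 log units; within the scatter) and a 1.9-fold higher number from compound 2 to compound 3 (0.29 log units; within the scatter) stay within the scatter. Three different small groups at this aromatic carbon thus give numbers spread over a narrow band, and a fourth is expected to land in the same band. For compound 4 the expected step is a 1.1-fold lower number from compound 3 to compound 4 (0.03 log units; within the scatter). The estimate for compound 4 is therefore 250 nM, with a range from 80 nM to 800 nM.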

Compound 4, half-maximal effective concentration: 6.5 nM
Beside the measured number, compound 4's estimate is 38-fold (1.59 log units) above it, and the stated range ends above it.
By their numbers in this assay, from the lowest: compound 4; then compounds 2, 3 and 1 (each within the scatter of the next, the first and the last beyond it).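

At this aromatic carbon, ortho to an isopropoxy group, the choice of group matters far more in this assay than the narrow band of the first three compounds suggested: the steps are a 42-fold lower number from compound 3 to compound 4 (1.62 log units; beyond the scatter) and a 22-fold lower number from compound 2 to compound 4 (1.33 log units; beyond the scatter) and an 82-fold lower number from compound 1 to compound 4 (1.91 log units; beyond the scatter) and all are large. Methoxy and cyano match in the counts of heavy atoms and hydrogen-bond acceptors, so those counts do not separate them. Nothing available here gives a measured reason for this difference. The compounds shown leave open how a trifluoromethyl group, an amide or a longer nitrile-bearing chain would behave at this carbon. They also leave open whether cyano would give a similar step if the isopropoxy group were replaced by a methoxy group.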